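This account rests on a few compounds, and the source may have more. Where it says the series, first, only, none or still open, it means among the compounds named here.

Compound 1, `COc1ccc(C2=C(c3cc(OC)c(OC)c(OC)c3)C(=O)CC2O[SiH2]C(C)(C)C)cc1OC`: in an ADME assay on HEK293 cells (Homo sapiens) for cytotoxicity, read by MTT assay, with a stated time of 72 h (on this read-out higher numbers stand for weaker inhibition and lower numbers for stronger inhibition), compound 1 gives > 100 ug/mL, which is a limit of the assay and not a number.
Compound 2, `COc1ccc(C2=C(c3cc(OC)c(OC)c(OC)c3)C(=O)C(OC(C)=O)C2)cc1Cl`: in this assay compound 2 gives 60 ug/mL.
Compound 3, `COc1ccc(C2=C(c3cc(OC)c(OC)c(OC)c3)C(=O)C(OC(C)=O)C2)cc1O`: in this assay compound 3 gives 92 ug/mL.

Two of the three values are numbers, and compound 3 gives one of them; the other belongs to compound 2. The measured step between these two is a 1.5-fold higher number from compound 2 to compound 3 (0.19 log units; within the scatter), so the pair stands close together. Compound 1 sits at the limit of > 100 ug/mL in this assay, at which 1 of the 3 values shown sits, which tells only where the assay stops reading.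

Compound 4, `COc1ccc(C2=C(c3cc(OC)c(OC)c(OC)c3)C(=O)C(OC(C)=O)C2)cc1OC(C)C`, differs from compound 3 in one place: isopropyl in place of hydrogen on an oxygen on an aromatic ring. Among the compounds with values here, no measured step bears directly on this change. Within the data shown here, the single step measured, a 1.5-fold higher number from compound 2 to compound 3 (0.19 log units; within the scatter), puts hydroxy in place of chloro on an aromatic carbon, a different kind of exchange from the one in hand, and it stayed within the scatter. Nothing seen so far therefore points to a step beyond the scatter in either direction in this assay for compound 4. Compound 4 is expected to give 85 ug/mL, with a range of 45 ug/mL to 160 ug/mL. The step that this estimate means, a 1.1-fold lower number from compound 3 to compound 4 (0.03 log units; within the scatter), is expected to fall within the scatter.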

Compound 4, half-maximal inhibitory concentration: > 100 ug/mL
Compound 4: no number, only a limit (the forecaster's own chance of this, stated with the estimate: 35%); at least 1.1-fold (0.07 log units) between middle value and limit.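

In this assay compound 4 gives > 100 ug/mL, which is a limit of the assay and not a number, so isopropyl on this oxygen gives no value that can be placed exactly against the hydroxy or chloro compounds. The exchange of hydrogen for isopropyl reads as an at least 1.0-fold higher number from compound 3 to compound 4 (0.03 log units; that floor lies within the scatter), and the exchange of chloro for isopropoxy reads as an at least 1.6-fold higher number from compound 2 to compound 4 (0.22 log units; that floor lies within the scatter); each is only a floor, so neither establishes a change beyond the scatter, and neither excludes a larger one. What this position adds is a second compound that can be read only as a limit, and the series now has fewer exact numbers to compare than its size suggests: the limit of > 100 ug/mL in this assay, at which 2 of the 4 values shown sit.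

Going by these compounds, how far the true value of compound 4 lies past the end of the reading stays unknown, and with it the real size of the change from hydroxy to isopropoxy. Also open, on these data alone, is how this assay would read with a longer chain on this oxygen, or with an amine or a carboxylic acid on this aromatic carbon.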